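Chloro Substitution on the Amide Aryl of Compound 2

The source may hold more compounds than are shown below. What is called first, only, known or untested is meant among the compounds shown, and "the series" means these compounds.

Compound 1 `Cc1nc(-c2ccc(Cl)cc2)sc1C1SCC(=O)N1c1ccc(Cl)cc1` gives 45.7% in a functional assay on the whole organism (strain Wistar albino) for inhibition, with Rattus norvegicus as the target, read by paw edema, with stated times of 1 h and 2 h, at a dose of 40 mg/kg by the oral route; a higher number here means more inhibition at the dose given (going by the name of the read-out), a lower number less inhibition. Compound 2 `Cc1nc(Cc2ccc(Cl)cc2)sc1C1SCC(=O)N1c1ccccc1` differs from compound 1 in two places at once. In this assay compound 2 is reported as "not active" (no number reported), so it stands on no single number. Compound 3 `Cc1nc(Cc2ccc(Cl)cc2)sc1C1SCC(=O)N1c1ccc(Cl)cc1` has not been measured. From compound 2 to compound 3 the change is chloro in place of hydrogen on an aromatic carbon. For the measured compounds named here, no step between measured compounds isolates this change; since compound 1, which also carries a 4-chlorophenyl, reaches 45.7%, a gain beyond the scatter is expected for compound 3, though smaller than that figure. Compound 3 is expected to give about 25%, in the range 5% to 45%.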

Compound 3, a percentage reported as inhibition, in the whole organism at one dose (the size of the read-out at that dose, not a potency): 40.1%
Beside the measured number, compound 3's estimate is 15.1 percentage points below it; the measured number falls inside the stated range.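

Phenyl to 4-chlorophenyl separates compound 2, reported as not active, from compound 3 at 40.1% in this assay, so a measured response appears with this chloro, although no step size can be read against a result without a number. With 4-chlorobenzyl in place of 4-chlorophenyl, the change a number 5.6 percentage points lower from compound 1 to compound 3 (within the scatter) does not tell these two groups apart at this dose. Nothing available explains the result of the chloro change.

From the compounds shown here alone, whether fluoro, methyl or an amine at this place on the ring would serve as chloro does remains open.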